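Hexyl to ethylsulfanylpropyl on the core of compound 2

This account rests on a few compounds, and the source may have more. Where it says the series, first, only, none or still open, it means among the compounds named here.

Measured so far in a functional assay on ileum for inhibition of histamine H1 receptor (Cavia porcellus); on this read-out higher numbers stand for weaker inhibition and lower numbers for stronger inhibition:
compound 1 `CCCCN1CCCN(c2nc3ccccc3n2CCOCC)CC1`: 8.4 nM
compound 2 `CCCCCCn1c(N2CCN(C)CC2)nc2ccccc21`: 26 nM

Compound 2 gives the higher of the two numbers in this assay; compound 1 sits lower, and the gap between them lies beyond the scatter. Compound 3 `CCSCCCn1c(N2CCN(C)CC2)nc2ccccc21` differs from compound 2 by ethylsulfanyl in place of propyl on a saturated chain carbon, three bonds along the chain from an aromatic nitrogen. Going by the values given here, no measured pair shows this change, so the step from compound 2 to compound 3 is expected at a 1.2-fold higher number from compound 2 to compound 3 (0.06 log units; within the scatter), a small shift that may not exceed the scatter in either direction. Compound 3 is therefore estimated at 30 nM, with a range from 10 nM to 90 nM.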

Compound 3, half-maximal inhibitory concentration: 530 nM
Estimate against measurement, compound 3: 18-fold (1.25 log units) below; measured number outside the range, above it.
By their numbers in this assay, from the lowest: compound 1; then compound 2; then compound 3.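

On the core of compound 2, hexyl to 3-(ethylsulfanyl)propyl is a large loss in this assay, with a 20-fold higher number from compound 2 to compound 3 (1.31 log units; beyond the scatter), although the leaving propyl and entering ethylsulfanyl each hold 3 heavy atoms. This position on the chain therefore distinguishes between these two groups despite that equal count, which compounds 1 and 2 alone could not show. Nothing available here explains the loss. Still open, from the compounds shown here alone, is whether 3-ethoxypropyl, with oxygen in place of sulfur, or a chain ending in an amine would return the number towards that of compound 2.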